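A few compounds are considered here, and "the series" means these few. Any claim that something is new, unique, unknown or untested is made for them only; others in the source may bear on it.

Values measured in an ADME assay on MT4 cells (Homo sapiens) for cytotoxicity, read by MTT assay, with a stated time of 96 h; on this read-out higher numbers stand for lower toxicity in this test and lower numbers for higher toxicity in this test:

- Compound 1 `NS(=O)(=O)c1ccc(N2N=C(c3ccccc3)CC2c2ccccc2F)cc1`: 42000 nM
- Compound 2 `NS(=O)(=O)c1ccc(N2N=C(c3ccc(OCc4ccccc4)cc3)CC2c2ccccc2)cc1`: > 100000 nM (a limit of the assay, not a number)
- Compound 3 `NS(=O)(=O)c1ccc(N2N=C(c3ccc(Oc4ccccc4)cc3)CC2c2ccccc2)cc1`: 42000 nM

As far as these compounds go, compound 2 gives only a limit in this assay, so its true position on the scale is unknown. It is the least clearly placed of the three compounds, and any step that starts from it is a bound and not an exact size.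

Compound 4 `NS(=O)(=O)c1ccc(N2N=C(c3ccc(OCc4ccccc4)cc3)CC2c2cccc(Cl)c2)cc1` is compound 2 with one change: chloro in place of hydrogen on an aromatic carbon. In words, chloro takes the place of hydrogen on an aromatic carbon, turning a phenyl into a 3-chlorophenyl.

Going by the values given here, no measured pair shows this change directly. The nearest evidence is an at least 2.3-fold lower number from compound 2 to compound 3 (0.37 log units; beyond the scatter), a step at a different place in the molecule, on the group attached to the oxygen. It shows that a single change can bring this series from the limit down to a measurable number, and it gives a rough scale of at least modest size. A modest move towards a lower number is therefore expected, though the assay may again report only a limit. The expected step is an at least 1.4-fold lower number from compound 2 to compound 4 (0.15 log units; that floor lies within the scatter). For compound 4 the estimate is 70000 nM, with an expected range of 30000 nM to 100000 nM.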

Compound 4, half-maximal cytotoxic concentration: 36000 nM
Beside the measured number, compound 4's estimate is 1.9-fold (0.29 log units) above it; the range from low to high includes it.
By their numbers in this assay, from the lowest: compounds 4, 1 and 3 (each within the scatter of the next). At a limit, above all of these: compound 2.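

Chloro in place of hydrogen, turning a phenyl into a 3-chlorophenyl, gives an at least 2.7-fold lower number from compound 2 to compound 4 (0.44 log units; beyond the scatter) in this assay. The earlier compounds shown here showed a step of this kind only on the group attached to the oxygen, whereas this one shows that a single added chlorine, meta to a large group on a different aromatic ring, is also enough to bring compound 2 from the limit to a measurable number, here towards higher toxicity in this test. The step is only a floor and its true size stays unknown, because compound 2 sits at a limit and not at a number: the limit of > 100000 nM in this assay, at which 1 of the 4 values shown sits.

The compounds shown leave open whether this step belongs to chloro in particular or would also appear with another group at the same place, such as fluoro, methyl, methoxy or an amine, and whether chloro on another carbon of that ring would do the same. They also leave open whether the same change would give a step of similar size on compound 3, where phenyl stands on the oxygen in place of benzyl.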